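Configuration-Only Changes Within a Shared Core

The source may hold more compounds than are shown below. What is called first, only, known or untested is meant among the compounds shown, and "the series" means these compounds.

Compound 1, `CC(=O)OC[C@H]1O[C@H](OC2=CC(=O)c3ccccc3C2=O)[C@H](OC(C)=O)[C@@H](OC(C)=O)[C@H]1OC(C)=O`, gives 9180 nM in a functional assay on MDA-MB-231 cells (Homo sapiens) for cytotoxicity, read by sulforhodamine B assay, with a stated time of 72 h; on this read-out lower numbers stand for stronger inhibition and higher numbers for weaker inhibition.
Compound 2, `CC(=O)OC[C@H]1O[C@@H](OC2=CC(=O)c3ccccc3C2=O)[C@H](OC(C)=O)[C@@H](OC(C)=O)[C@H]1OC(C)=O`, gives 13300 nM in this assay.
Compound 3, `CC(=O)OC[C@H]1O[C@@H](OC2=CC(=O)c3ccccc3C2=O)[C@H](OC(C)=O)[C@@H](OC(C)=O)[C@@H]1OC(C)=O`, gives 12600 nM in this assay.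

On these three numbers compound 3 stands second highest. Its nearest neighbour is compound 2, with a 1.1-fold lower number from compound 2 to compound 3 (0.02 log units; within the scatter); the furthest is compound 1, with a 1.4-fold higher number from compound 1 to compound 3 (0.14 log units; within the scatter). Both steps lie within the scatter, so no order among the three can be read from them.

Compound 4, `CC(=O)OC[C@H]1O[C@H](OC2=CC(=O)c3ccccc3C2=O)[C@H](OC(C)=O)[C@@H](OC(C)=O)[C@@H]1OC(C)=O`, is the next member of this set. the two compounds have the same atoms and bonds and differ only in configuration as drawn: 1 of 5 stereo elements differ; a stereocentre at a saturated ring carbon is drawn S in compound 3 and R in compound 4

All three measured steps bear on this change, since each pair differs only in configuration as drawn (the fact that compounds 1 and 2 differ only in the configuration as drawn, (the fact that compounds 1 and 3 differ only in the configuration as drawn), (the fact that compounds 2 and 3 differ only in the configuration as drawn)). They were a 1.4-fold higher number from compound 1 to compound 2 (0.16 log units; within the scatter), a 1.4-fold higher number from compound 1 to compound 3 (0.14 log units; within the scatter) and a 1.1-fold lower number from compound 2 to compound 3 (0.02 log units; within the scatter), every one within the scatter. A further change of one stereocentre at a saturated ring carbon is therefore expected to give no step beyond the scatter in this assay, that is a 1.1-fold lower number from compound 3 to compound 4 (0.04 log units; within the scatter) is expected.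

For compound 4 the estimate in this assay is 11500 nM, with a range from 6500 nM to 20000 nM.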

Compound 4, half-maximal inhibitory concentration: 8290 nM
Compound 4: middle estimate off by 1.4-fold (0.14 log units), on the high side; measured number inside the range.
By their numbers in this assay, from the lowest: compounds 4, 1, 3 and 2 (each within the scatter of the next).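

The change at this stereocentre on a saturated ring carbon gives a 1.5-fold lower number from compound 3 to compound 4 (0.18 log units; within the scatter), and the other two steps into compound 4, a 1.1-fold lower number from compound 1 to compound 4 (0.04 log units; within the scatter) and a 1.6-fold lower number from compound 2 to compound 4 (0.21 log units; within the scatter), also stay within the scatter. The same stereocentre, changed in the opposite sense, gave a 1.4-fold higher number from compound 1 to compound 2 (0.16 log units; within the scatter), so this centre has now been changed with the other varied stereocentre in both of its drawn configurations, without a step beyond the scatter in this assay. None of the six steps among the four compounds can be read as an order, and this newest comparison involves configuration alone: the fact that compounds 3 and 4 differ only in the configuration as drawn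

The compounds shown leave open whether configuration would matter if the acetate esters gave way to free hydroxyl groups or an amine. They also leave open whether any change other than one of configuration would move the number beyond the scatter in this assay.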